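Acid series: pyridyl to dichloropyridyloxy exchange

The source may hold more compounds than are shown below. What is called first, only, known or untested is meant among the compounds shown, and "the series" means these compounds.

Two compounds of the series have a number in an assay for inhibition of inositol hexakisphosphate kinase 2 (Homo sapiens), read by colorimetric assay, coupled enzyme assay and malachite green, with a stated time of 120 min, in the presence of a further agent that is not named here; a lower number here means a stronger inhibitor, a higher number a weaker inhibitor. Compound 1 `CNC(=O)c1ccc2noc(-c3ccccc3)c2c1` gives 2120 nM in this assay. Compound 2 `O=C(O)c1ccc2noc(-c3ccc(-c4ccncc4)cc3)c2c1` gives 150 nM in this assay, the lowest of the two numbers; the gap to compound 1 lies beyond the usual scatter, but the two structures differ in more than one place, so the two values themselves are all that can be said of this pair.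

Compound 3 `O=C(O)c1ccc2noc(-c3ccc(Oc4ncc(Cl)cc4Cl)cc3)c2c1` has not yet been measured in this assay. It differs from compound 2 in one place: (3,5-dichloropyridin-2-yl)oxy in place of pyridin-4-yl on an aromatic carbon. Within the data shown here, no measured pair follows a change of this kind, so no step size can be drawn from the data for it. Because compound 2 gives 150 nM and the series holds no guidance for this exchange, the expected step of a 1.7-fold higher number from compound 2 to compound 3 (0.22 log units; within the scatter) is no change beyond the scatter, in either direction. Compound 3 is therefore estimated at 250 nM in this assay, within a range of 80 nM to 800 nM.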

Compound 3, half-maximal inhibitory concentration: 650 nM
Compound 3: the middle estimate sits 2.6-fold (0.41 log units) below what was measured, and the stated range covers the measured number.
By their numbers in this assay, from the lowest: compound 2; then compound 3; then compound 1.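

In this assay, among these compounds, the exchange of pyridin-4-yl for (3,5-dichloropyridin-2-yl)oxy gives a 4.3-fold higher number from compound 2 to compound 3 (0.64 log units; beyond the scatter) and is the first readable step at this position, on an aromatic carbon of a six-membered aromatic ring of carbon only, para to a large group. The number at this position therefore depends on the group it carries, although the step is modest: the entering group has 9 heavy atoms against 6 for the leaving group, adds an oxygen and two chlorine atoms, and keeps one six-membered aromatic ring with 1 hetero atom, while compound 3 still gives 650 nM in the series. No measurement in hand bears on the origin of this step.

The single exchange changes the oxygen link, the two chlorine atoms and the point of attachment of the pyridine ring together, so the compounds shown do not divide the step among these features. A pyridin-2-yloxy group without chlorine, or a 3,5-dichloropyridin-2-yl group joined directly to the ring without the oxygen, would separate those contributions.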